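Ester replacement on the nitro core: pyridyl to thienyl

This account rests on a few compounds, and the source may have more. Where it says the series, first, only, none or still open, it means among the compounds named here.

Compound 1 `O=C(OC1CCC(CN2CCN(c3cc(=O)c4cc(C(F)(F)F)cc([N+](=O)[O-])c4s3)CC2)CC1)c1ccncc1` is the ester of the series with a nitro group on the core. In an ADME assay on cells (Hepatocyte, Homo sapiens) for metabolic stability, with a stated time of 30 min (on this read-out lower numbers stand for a less stable compound and higher numbers for a more stable compound), compound 1 gives 1%, the second highest of three numbers, within the scatter of compound 3 `Nc1cc(C(F)(F)F)cc2c(=O)cc(N3CCN(CC4CCCCC4)CC3)sc12` at 0.9% and far below compound 2 `Nc1cc(C(F)(F)F)cc2c(=O)cc(N3CCN(CC4CCC(O)CC4)CC3)sc12` at 72.9%. Going by the values given here, the only step between measured compounds, a number 72 percentage points lower from compound 2 to compound 3 (beyond the scatter), concerns a different part of the molecule and does not bear on the present change. Compound 4 `O=C(OC1CCC(CN2CCN(c3cc(=O)c4cc(C(F)(F)F)cc([N+](=O)[O-])c4s3)CC2)CC1)c1cccs1` differs from compound 1 by thiophen-2-yl in place of pyridin-4-yl on a carbonyl carbon. Among the compounds with values here, no measured pair speaks to this change, so little movement beyond the scatter is expected; compound 4 is expected at 2% (range 0% to 15%), an expected step of a number 1 percentage points higher from compound 1 to compound 4 (within the scatter).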

Compound 4, percent of the compound remaining: 2.2%
Compound 4: middle estimate off by 0.2 percentage points, on the low side; the range from low to high includes it.
By their numbers in this assay, from the lowest: compounds 3, 1 and 4 (each within the scatter of the next); then compound 2.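

In this assay, going by these compounds alone, thiophen-2-yl in place of pyridin-4-yl on the carbonyl carbon gives a number 1.2 percentage points higher from compound 1 to compound 4 (within the scatter) as the first reading at this position. Exchanging the six-membered aromatic ring with nitrogen for the five-membered aromatic ring with sulfur therefore does not separate the two esters on this read-out. No supporting measurement bears on this result.

From the compounds shown here alone, whether a saturated group such as cyclohexyl or a short alkyl chain on the carbonyl carbon would separate from these two aromatic rings remains open. Also open, going by these compounds, is whether an amide in place of the ester would change the reading.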